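Working notes: chloro substitution at the phenyl of compound 1

The source may hold more compounds than are shown below. What is called first, only, known or untested is meant among the compounds shown, and "the series" means these compounds.

Measured so far:
compound 1 `Cc1ccccc1-c1n[nH]c(-c2ccccc2)n1` gives 10 mg/kg in a functional assay on the whole organism (Cricetulus griseus) with Cricetinae gen. sp. as the target; on this read-out lower numbers stand for an effect already at smaller amounts and higher numbers for an effect only at larger amounts of compound
compound 2 `Cc1ccc(-c2n[nH]c(-c3ccccc3)n2)c(C)c1` gives only a limit of the assay, > 5 mg/kg
compound 3 `Cc1ccccc1-c1n[nH]c(-c2ccccc2C)n1` gives only a limit of the assay, > 10 mg/kg

For the measured compounds named here, compound 1 holds the only actual number in this assay; the other two results are limits. Adding a methyl on an aromatic carbon gives a step that the limit leaves unreadable from compound 1 to compound 2 and a number no lower from compound 1 to compound 3 (the limit leaves the size open). Neither step can be sized, as each rests on a value that sits at a limit: the limit of > 10 mg/kg in this assay, at which 1 of the 3 values shown sits, for compound 3, the limit of > 5 mg/kg in this assay, at which 1 of the 3 values shown sits, for compound 2. Going by these compounds, whether the two methyl additions weakened the effect or merely fell beyond the doses tested remains open.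

Compound 4 `Cc1ccccc1-c1n[nH]c(-c2cccc(Cl)c2)n1` differs from compound 1 by chloro in place of hydrogen on an aromatic carbon. Both measured steps concern a methyl, not a chloro, and both are unreadable, so they give no direction for this change. The expectation therefore rests on compound 1 alone, with wide uncertainty, and a real chance that this assay again reports only a limit.

Compound 4 is estimated at 12 mg/kg, with a range from 5 mg/kg to 30 mg/kg. For compound 4 the expected step is a 1.2-fold higher number from compound 1 to compound 4 (0.08 log units; within the scatter), essentially none beyond the scatter.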

Compound 4, dose for half-maximal effect: > 20 mg/kg
Compound 4 ended at the assay's limit (the forecaster's own chance of this, stated with the estimate: 35%); at least 1.6-fold (0.22 log units) between middle value and limit.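

In this assay compound 4 returns only a limit, > 20 mg/kg, so chloro at this place yields no actual number. Unlike the two methyl steps, whose sizes cannot be read, the change from hydrogen to chloro on an aromatic carbon, meta to a large group, does carry a floor: an at least 2.0-fold higher number from compound 1 to compound 4 (0.30 log units; that floor lies within the scatter). That floor does not separate the change from the usual scatter, but compound 1 remains the only compound shown with an actual number, and nothing here shows chloro at this place bringing the effect to smaller amounts.

Going by these compounds, whether the true value of compound 4 lies just past its limit or far beyond it stays open, so the real size of the chloro step is unknown. Also open, on these data alone, is whether a methoxy group, an amine or a carboxylic acid at the same place would give an actual number rather than a limit, and whether chloro elsewhere on this ring would behave as it does in compound 4.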